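The compounds below may be only part of what the source reports. "The series", "measured", "known", "first", "only" and "open" are said of these compounds alone.

Working notes on the series. In a functional assay (brain) for inhibition, with Rattus norvegicus as the target (on this read-out higher numbers stand for weaker inhibition and lower numbers for stronger inhibition), compound 1 (`Cc1c(C)c2c(c(C)c1O)C(CN1CCCCC1)C(C)(C)O2`) gives 400 nM and compound 2 (`Cc1c(C)c2c(c(C)c1O)C(CN1CCN(c3ncccn3)CC1)C(C)(C)O2`) gives 400 nM, so the two are level within the scatter. Compound 3 (`Cc1c(C)c2c(c(C)c1O)C(CO)C(C)(C)O2`) is the next to be read against compound 1. The change is hydroxy in place of piperidin-1-yl on a saturated chain carbon bound to a saturated ring carbon. Within the data shown here, no measured step calibrates this change, so any forecast is loose. A modest weakening is expected, with an estimated step of a 2.3-fold higher number from compound 1 to compound 3 (0.35 log units; beyond the scatter). For compound 3 the expected value in this assay is 900 nM, with an estimated range of 200 nM to 3500 nM.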

Compound 3, half-maximal inhibitory concentration: 2600 nM
For compound 3 the middle estimate is 2.9-fold (0.46 log units) below the measured one; measured number inside the range.
By their numbers in this assay, from the lowest: compounds 1 and 2 (each within the scatter of the next); then compound 3.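

With hydroxy in place of piperidin-1-yl on a saturated chain carbon bound to a saturated ring carbon, the series shows a 6.5-fold higher number from compound 1 to compound 3 (0.81 log units; beyond the scatter) and thus its first difference at this place that lies beyond the scatter. The level values of compounds 1 and 2 gave no sign that this place could separate compounds. Nothing at hand gives a cause for this step. On these data alone, it remains open whether the weakening follows the loss of the piperidin-1-yl ring or the entry of hydroxy. A methoxy group, a dimethylamino group or a carboxylic acid at the same place would help separate these readings.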